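Aryl variation on the ring nitrogen: expectation for compound 3

The source may hold more compounds than are shown below. What is called first, only, known or untested is meant among the compounds shown, and "the series" means these compounds.

Measured compounds:
compound 1, `N#Cc1ccccc1-n1cc(COc2cccc(NC(=O)Nc3ccc(Cl)c(C(F)(F)F)c3)c2)nn1`, gives 1970 nM in a functional assay on HepG2 cells (Homo sapiens) for inhibition, read by MTT assay, with a stated time of 72 h; a higher number here means a weaker inhibitor, a lower number a stronger inhibitor
compound 2, `CCc1ccc(-n2cc(COc3cccc(NC(=O)Nc4ccc(Cl)c(C(F)(F)F)c4)c3)nn2)cc1`, gives 1950 nM in this assay

Compound 2 stands at the lowest of the two numbers, with compound 1 within the scatter of it: a 1.0-fold lower number from compound 1 to compound 2 (0.00 log units; within the scatter).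

Compound 3, `CC(C)c1ccccc1-n1cc(COc2cccc(NC(=O)Nc3ccc(Cl)c(C(F)(F)F)c3)c2)nn1`, differs from compound 2 by 2-isopropylphenyl in place of 4-ethylphenyl on an aromatic nitrogen. Among the compounds with values here, the only measured step that bears on this position is the aryl exchange a 1.0-fold lower number from compound 1 to compound 2 (0.00 log units; within the scatter), which produced no shift beyond the scatter. For compound 3 no step beyond the scatter is therefore expected in this assay, a 1.0-fold higher number from compound 2 to compound 3 (0.01 log units; within the scatter). The estimate for compound 3 is 2000 nM, with a range of 1000 nM to 4000 nM.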

Compound 3, half-maximal inhibitory concentration: 1900 nM
Beside the measured number, compound 3's estimate is 1.1-fold (0.02 log units) above it, and the stated range covers the measured number.
By their numbers in this assay, from the lowest: compounds 3, 2 and 1 (each within the scatter of the next).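

In this assay, 2-isopropylphenyl on the aromatic nitrogen stays within the scatter of 4-ethylphenyl (a 1.0-fold lower number from compound 2 to compound 3 (0.01 log units; within the scatter)) and also of 2-cyanophenyl (a 1.0-fold lower number from compound 1 to compound 3 (0.02 log units; within the scatter)). Isopropyl in place of cyano on an aromatic carbon is thus a second exchange at this aryl group without a shift beyond the scatter, and all three aryl groups shown give values within the scatter of one another. Nothing available explains this flat result.

Still open, going by these compounds, is whether an aryl group bearing an amine or a carboxylic acid would stay within the scatter. The same question holds for a longer alkyl chain in place of the aryl ring on this nitrogen.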